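A few compounds are considered here, and "the series" means these few. Any claim that something is new, unique, unknown or untested is made for them only; others in the source may bear on it.

Measured compounds:
compound 1 `O=C(CCCc1cn(S(=O)(=O)c2ccccc2)c2ccccc12)NCCCn1ccnc1` gives 13200 nM in an assay on isolated protein for activation of Insulin-degrading enzyme (Homo sapiens), read by fluorescence, with stated times of 10 min and 20 min; a lower number here means that less compound is needed, a higher number that more compound is needed for the effect
compound 2 `O=C(CCCc1cn(S(=O)(=O)c2ccccc2)c2ccccc12)NCCCCn1ccnc1` gives 8130 nM in this assay

For the measured compounds named here, compound 2 holds the lowest of the two numbers in this assay, but the only other number, that of compound 1, lies within the scatter of it, so the two are not separated. Going by the values given here, the one measured step, a 1.6-fold lower number from compound 1 to compound 2 (0.21 log units; within the scatter), is itself within the scatter.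

Compound 3 `CN(CCCn1ccnc1)C(=O)CCCc1cn(S(=O)(=O)c2ccccc2)c2ccccc12` is unmeasured. It differs from compound 2 by a group of 10 heavy atoms (7 carbon, 3 nitrogen; one five-membered aromatic ring with 2 hetero atoms) in place of a group of 10 heavy atoms (7 carbon, 3 nitrogen; one five-membered aromatic ring with 2 hetero atoms), on a carbonyl carbon. The amide-type nitrogen of compound 2 thus loses its hydrogen and carries a methyl instead, with the chain otherwise unchanged. Among the compounds with values here, no measured step touches this position: the step from compound 1 to compound 2 concerns the chain length on the other side of that nitrogen and gives no guide to methylation of it. Nothing in the two measured compounds supports a change beyond the scatter in either direction in this assay, so the expected step of a 1.1-fold higher number from compound 2 to compound 3 (0.04 log units; within the scatter) is set near zero, with a wide range to reflect the absence of any bearing data. Compound 3 is therefore estimated at 9000 nM, with a range of 3000 nM to 30000 nM in this assay.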

Compound 3, half-maximal effective concentration: 14100 nM
Beside the measured number, compound 3's estimate is 1.6-fold (0.19 log units) below it; the range from low to high includes it.
By their numbers in this assay, from the lowest: compounds 2, 1 and 3 (each within the scatter of the next).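

The step that reads this position directly in this assay is a 1.1-fold higher number from compound 1 to compound 3 (0.03 log units; within the scatter): with the 3-(1H-imidazol-1-yl)propyl chain kept, methyl in place of hydrogen on the amide-type nitrogen does not separate the two compounds, so in this pair the amide hydrogen shows no bearing on the number. The pair with the same atoms joined differently gives a 1.7-fold higher number from compound 2 to compound 3 (0.24 log units; within the scatter), so on the carbonyl carbon the (3-(1H-imidazol-1-yl)propyl)(methyl)amino group is not told apart from the group it replaces in compound 2. No explanation can be offered for these small steps, as nothing measured beyond the numbers themselves bears on them.

Still open, as far as these compounds go, is whether a larger group on the amide-type nitrogen, such as ethyl or benzyl, would give a step beyond the scatter in this assay, and whether methyl there behaves the same on a longer chain. The three compounds also say nothing about the imidazole end of the chain, where a primary amine or a carboxylic acid would test whether that ring matters to the number at all.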